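Acid-Bearing Side Chain Swap in the Shared-Core Series

The compounds below may be only part of what the source reports. "The series", "measured", "known", "first", "only" and "open" are said of these compounds alone.

Measured compounds:
compound 1 `O=C(O)[C@@H]1CCCN1C(=O)CN(c1nc(Cl)nc2[nH]cnc12)C1CC1`: 26%
compound 2 `O=C(OCc1ccccc1)[C@@H]1CCCN1C(=O)CN(c1nc(Cl)nc2[nH]cnc12)C1CC1`: 43.3%

Within the data shown here, in a functional assay on the whole organism (Tail, strain ICR) with Mus musculus as the target, in the tail flick test, with a stated time of 90 min, at a dose of 25 umol/kg by the oral route (a lower number here means a weaker effect, a higher number a stronger effect of the compound at the dose given), compound 1 gives 26%, the lower of the two measured numbers; the only measured step, a number 17.3 percentage points higher from compound 1 to compound 2 (beyond the scatter), is a modest rise on going to the benzyl ester, so compound 1 stands at the bottom of what has been seen so far.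

Compound 3 `C[C@@H](O)[C@H](NC(=O)CN(c1nc(Cl)nc2[nH]cnc12)C1CC1)C(=O)O` is not yet measured. It differs from compound 1 in this: (1-carboxy-2-hydroxypropyl)amino in place of 2-carboxypyrrolidin-1-yl on a carbonyl carbon. Among the measured compounds shown here, the free carboxylic acid is kept, so the one measured step, which concerns esterification of that acid, does not bear on this change; no measured pair tells how the ring-opened, hydroxyl-bearing amino acid compares with the pyrrolidine acid. Without a relevant precedent the working assumption is that the acid-bearing acyclic side chain behaves much like the acid of compound 1, and the step of a number 1 percentage points lower from compound 1 to compound 3 (within the scatter) is expected to stay within the scatter, with the wider range reflecting the absence of any guiding step.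

Compound 3 is therefore estimated at 25% in this assay, within 8% to 45%.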

Compound 3, a percentage reported as activity, at one dose (the size of the read-out at that dose, not a potency): 35.9%
The estimate for compound 3 lay 10.9 percentage points below the measured number; the range from low to high includes it.
By their numbers in this assay, from the lowest: compounds 1, 3 and 2 (each within the scatter of the next, the first and the last beyond it).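

In this assay, exchanging 2-carboxypyrrolidin-1-yl for (1-carboxy-2-hydroxypropyl)amino on a carbonyl carbon whose other neighbours are saturated chain carbon gives a number 9.9 percentage points higher from compound 1 to compound 3 (within the scatter). Among these compounds, this is the first information on the side chain itself rather than on its acid: in this one pair, the five-membered ring can give way to an open chain bearing a hydroxyl group, with a free carboxylic acid present on both sides, without a step beyond the scatter. No accompanying measurement bears on this result, so the step stands as an observation only.

Going by these compounds, it remains open whether the benzyl ester, which gave a number 17.3 percentage points higher from compound 1 to compound 2 (beyond the scatter) on the pyrrolidine side chain, would produce a comparable step on the open side chain of compound 3. The separate roles of the hydroxyl group and the ring also remain unresolved, and an open chain ending in a methyl group in place of the hydroxyl group, or a primary amide in place of the carboxylic acid, would address the parts of this side chain that the present pair cannot separate.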